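This account rests on a few compounds, and the source may have more. Where it says the series, first, only, none or still open, it means among the compounds named here.

For the measured compounds named here, in an ADME assay on THP-1 cells (Homo sapiens) for cytotoxicity, read by flow cytometry and propidium iodide staining, with a stated time of 72 h (a higher number here means a weaker inhibitor, a lower number a stronger inhibitor), only two compounds have been read so far. Compound 1 (`COc1ccc(-c2oc3ccc(NC(C)=O)cc3c(=O)c2OC)cc1`) gives > 50000 nM, which is a limit of the assay and not a number. Going by the values given here, compound 2 (`COc1c(-c2ccccc2)oc2ccc(N)cc2c1=O`) gives 74000 nM, the only true number available, so its place can't be fixed against a second measured value.

The next compound to be tested is compound 3 (`COc1ccc(-c2oc3ccc(N)cc3c(=O)c2OC)cc1`). It departs from compound 2 by one change: methoxy in place of hydrogen on an aromatic carbon. This is methoxy in place of hydrogen on an aromatic carbon, para to a large group. Among the compounds with values here, no measured pair shows what such a change does in this assay, so there is no direct guide to its size or direction. The expectation therefore starts from compound 2 at 74000 nM, and no step beyond the usual scatter is foreseen. The estimated step of a 1.2-fold lower number from compound 2 to compound 3 (0.09 log units; within the scatter) stays within that scatter. For compound 3 the expected value is 60000 nM, with an estimated range from 25000 nM to 130000 nM.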

Compound 3, half-maximal inhibitory concentration: 21000 nM
For compound 3 the middle estimate is 2.9-fold (0.46 log units) above the measured one, outside the stated range (below it).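

In this assay, methoxy in place of hydrogen on an aromatic carbon, para to a large group, gives a 3.5-fold lower number from compound 2 to compound 3 (0.55 log units; beyond the scatter), the first measured sign that this position affects the read-out, with a step beyond the usual scatter. The nitrogen on the aromatic ring also proves to matter when the methoxy is kept, since hydrogen in place of acetyl there gives an at least 2.3-fold lower number from compound 1 to compound 3 (0.37 log units; beyond the scatter). The value of compound 1 is a limit of the assay and not a number, so the true size of that second step remains unknown: the limit of > 50000 nM in this assay, at which 1 of the 3 values shown sits.

On these data alone, the methoxy result rests on a single pair, so it remains open whether the lower number is specific to methoxy or would also appear with a hydroxyl, an ethoxy or a fluorine at the same place. As far as these compounds go, it is equally open how far the result at the nitrogen extends, for instance to a methylamine, a dimethylamine or an amide with a longer chain, and whether the methoxy step would keep its size with any of these groups on the nitrogen.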